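The source may hold more compounds than are shown below. What is called first, only, known or untested is meant among the compounds shown, and "the series" means these compounds.

Of the compounds shown here, three sharing one core have been measured. Compound 1 is `Cc1ccc(C2=NN(c3nc(-c4ccccc4)cs3)C(c3ccc(F)cc3)C2)s1`. In a functional assay on A549 cells (Homo sapiens) for antiproliferative activity, read by XTT assay, with a stated time of 24 h (a lower number here means a stronger inhibitor, a higher number a weaker inhibitor), compound 1 gives > 500 ug/mL, which is a limit of the assay rather than a number. Compound 2 is `Cc1ccc(C2=NN(c3nc(-c4ccc(Br)cc4)cs3)C(c3ccc(F)cc3)C2)s1`. In this assay compound 2 gives > 500 ug/mL, again a limit of the assay. Compound 3 is `CS(=O)(=O)c1ccc(-c2csc(N3N=C(c4ccc(Cl)s4)CC3c3ccc(F)cc3)n2)cc1`. In this assay compound 3 gives > 500 ug/mL, also a limit of the assay. Within the data shown here, the only single-place step among them, bromo in place of hydrogen on an aromatic carbon, reads a step that the two limits leave unreadable from compound 1 to compound 2, so nothing about its size can be read. Compound 3 thus stands where every measured compound stands, at the limit of > 500 ug/mL in this assay, at which 3 of the 3 values shown sit.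

Compound 4 is `Cc1ccc(C2=NN(c3nc(-c4ccc(S(C)(=O)=O)cc4)cs3)C(c3ccc(F)cc3)C2)s1`. It differs from compound 3 by methyl in place of chloro on an aromatic carbon; cut one bond further out, the difference reads 5-chlorothiophen-2-yl to 5-methylthiophen-2-yl. Among the measured compounds shown here, no measured step touches this position, and the one measured step was unreadable because both its values sit at the limit of > 500 ug/mL in this assay, at which 3 of the 3 values shown sit. For compound 4 the expectation is that the change adds nothing readable, and the step is estimated as a step that the limit leaves unreadable from compound 3 to compound 4. For compound 4 the estimate in this assay is 600 ug/mL, with a range from 250 ug/mL to 1500 ug/mL, most likely reported again only as a limit.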

Compound 4, half-maximal inhibitory concentration: > 500 ug/mL
Compound 4 was reported as a limit (the forecaster's own chance of this, stated with the estimate: 85%); the middle value lies beyond the limit too.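

In this assay compound 4 gives > 500 ug/mL which is again a limit of the assay. Among these compounds, no step among compound 1, compound 2, compound 3 and compound 4 can be read, because all four stop at the same limit: the limit of > 500 ug/mL in this assay, at which 4 of the 4 values shown sit. The compounds shown leave open which change to the shared core, if any, would give a real number in this assay and not a limit.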